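The source may hold more compounds than are shown below. What is called first, only, known or untested is meant among the compounds shown, and "the series" means these compounds.

Compound 1 `O=C1C=C(NCc2ccccc2)C(=O)c2c1nc1n2[C@H]2OC[C@@H](O)[C@H]2OC1` in a functional assay on ECa-109 cells for inhibition, with ECa-109 cell line (Homo sapiens) as the target, read by sulforhodamine B assay (on this read-out lower numbers stand for stronger inhibition and higher numbers for weaker inhibition), gives > 8000 nM, which is a limit of the assay and not a number.
Compound 2 `CCc1ccc(NC2=CC(=O)c3nc4n(c3C2=O)[C@H]2OC[C@@H](O)[C@H]2OC4)cc1` gives 3080 nM.
Compound 3 `O=C1C=C(NC2CCCC2)C(=O)c2c1nc1n2[C@H]2OC[C@@H](O)[C@H]2OC1` gives > 16000 nM, again a limit rather than a number.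

Compound 3 thus stands only at the limit of > 16000 nM in this assay, at which 1 of the 3 values shown sits, and among the three values shown one other is also a limit, so only compound 2 has a number. Compound 4 `CCCN(CCC)C1=CC(=O)c2nc3n(c2C1=O)[C@H]1OC[C@@H](O)[C@H]1OC3` is not yet measured and differs from compound 3 in one place: dipropylamino in place of cyclopentylamino on a double-bonded ring carbon. Two measured steps end at compound 3. The step that the two limits leave unreadable from compound 1 to compound 3 cannot be read, since both of its ends are limits. The step of an at least 5.1-fold higher number from compound 2 to compound 3 (0.71 log units; beyond the scatter) shows the 4-ethylphenyl group giving a number where benzyl and cyclopentyl give only limits. Dipropylamino, like cyclopentylamino, carries no ring, and nothing among these three compounds shows such a group reaching a number. Compound 4 is therefore expected to stay weak, with a step that the limit leaves unreadable from compound 3 to compound 4, and a limit is again the likely result. The estimate for compound 4 is 20000 nM, in a range from 8000 nM to 60000 nM.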

Compound 4, half-maximal inhibitory concentration: > 16000 nM
Compound 4: a limit, no number; the forecaster's own chance of this, stated with the estimate: 70%; the middle value is on the limit's open side.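

In this assay, dipropylamino on this double-bonded ring carbon, with no ring and no hydrogen-bond donor, ends at a limit and not a number, just as cyclopentylamino did: the limit of > 16000 nM in this assay, at which 2 of the 4 values shown sit.
Among these compounds, then, neither form of amine without an aromatic ring gives a number, whether it keeps its hydrogen-bond donor or not, and swapping (4-ethylphenyl)amino for dipropylamino gives an at least 5.1-fold higher number from compound 2 to compound 4 (0.71 log units; beyond the scatter). The steps from compound 1 and compound 3 to compound 4 cannot be read, since both ends of each are limits.

On these data alone, how far compound 1, compound 3 and compound 4 lie beyond their limits stays open, so they cannot be ranked against one another. Also open, as far as these compounds go, is whether a plain phenylamino group would give a number, which would show whether the aromatic ring on the nitrogen is enough without the ethyl group.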